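A few compounds are considered here, and "the series" means these few. Any claim that something is new, unique, unknown or untested is made for them only; others in the source may bear on it.

Of the compounds shown here, three sharing one core have been measured in an assay on CHO cells for antagonist activity at transient receptor potential cation channel subfamily V member 1 (Homo sapiens), read by FLIPR; a higher number here means a weaker inhibitor, a lower number a stronger inhibitor. Among the measured compounds shown here, compound 1 `Cc1cccc(N2CCN(c3cc(C(F)(F)F)ccc3CNC(=O)C(C)c3ccc(NS(C)(=O)=O)c(F)c3)CC2)c1` gives 1.8 nM in this assay, and compound 2 `COc1ccc(N2CCN(c3cc(C(F)(F)F)ccc3CNC(=O)C(C)c3ccc(NS(C)(=O)=O)c(F)c3)CC2)cc1` gives 1.6 nM in this assay; the single step between them, a 1.1-fold lower number from compound 1 to compound 2 (0.05 log units; within the scatter), puts 4-methoxyphenyl in place of 3-methylphenyl on an amine nitrogen in a ring. Compound 3 `CC(C)COc1cc(C(F)(F)F)ccc1CNC(=O)C(C)c1ccc(NS(C)(=O)=O)c(F)c1` gives 0.8 nM in this assay, the lowest of the three numbers; compound 2 stands nearest to it, a gap within the scatter, while compound 1 stands furthest, a gap beyond the scatter.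

Compound 4 `CCCCCc1cc(C(F)(F)F)ccc1CNC(=O)C(C)c1ccc(NS(C)(=O)=O)c(F)c1` has not yet been measured. It differs from compound 3 by pentyl in place of isobutoxy on an aromatic carbon. For the measured compounds named here, no measured step bears on this place: the only step known, from compound 1 to compound 2, is at the amine nitrogen in a ring and is within the scatter, so it says nothing about what pentyl in place of isobutoxy on an aromatic carbon does. Lacking any step to lean on, the expectation for compound 4 in this assay is a step of a 1.5-fold higher number from compound 3 to compound 4 (0.18 log units; within the scatter), meaning no change beyond the scatter, though the range must be wide. Compound 4 is therefore estimated to give 1.2 nM in this assay, between 0.4 nM and 4 nM.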

Compound 4, inhibition constant: 0.4 nM
Estimate against measurement, compound 4: 3.0-fold (0.48 log units) above; measured number inside the range.
By their numbers in this assay, from the lowest: compounds 4, 3, 2 and 1 (each within the scatter of the next, the first and the last beyond it).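

At the aromatic carbon ortho to a large group and meta to a trifluoromethyl group, pentyl in place of isobutoxy gives a 2.0-fold lower number from compound 3 to compound 4 (0.30 log units; within the scatter) in this assay, the first step read at this place. The chain keeps its 5 heavy atoms and stays free of rings, but its oxygen gives way to carbon and its single hydrogen-bond acceptor is gone, and the step still stays within the scatter, so in this one pair the oxygen and its acceptor are not needed to keep the number at this level. Nothing measured here accounts for the step or shows what either chain does at this place.

The compounds shown leave open what a shorter or longer alkyl chain, a chain ending in an amine or a carboxylic acid, or a ring-bearing ether would do on this aromatic carbon in this assay. They also leave open whether pentyl in place of isobutoxy would give a similar step if a nitrile or a chlorine stood in place of the trifluoromethyl group.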